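Sulfonamide for sulfone on a bicyclic chain

A few compounds are considered here, and "the series" means these few. Any claim that something is new, unique, unknown or untested is made for them only; others in the source may bear on it.

Compound 1 `Cn1c(-c2ccccc2C(F)(F)F)nnc1C12CCC(CCS(C)(=O)=O)(CC1)CC2` gives > 4000 nM in an assay on CHO-K1 cells for inhibition of 11-beta-hydroxysteroid dehydrogenase type 2 (Mus musculus), read by scintillation proximity assay; on this read-out lower numbers stand for stronger inhibition and higher numbers for weaker inhibition.
Compound 2 `CCS(=O)(=O)CCC12CCC(c3nnc(-c4ccccc4C)n3C)(CC1)CC2` gives > 4000 nM in this assay.

In this assay neither value shown is a number. For compound 1 the read-out is only a limit of the assay, > 4000 nM. Compound 2 likewise stops at a limit, > 4000 nM. Both sit at the limit of > 4000 nM in this assay, at which 2 of the 2 values shown sit, so compound 1 cannot be placed anywhere inside the measured range; it stands, together with compound 2, at the edge of what the assay reports. Among the compounds with values here, no step between measured compounds is recorded.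

Compound 3 `Cn1c(-c2ccccc2C(F)(F)F)nnc1C12CCC(CNS(C)(=O)=O)(CC1)CC2` differs from compound 1 in one place: methanesulfonamido in place of (methylsulfonyl)methyl on a saturated chain carbon bound to a saturated ring carbon. With both measured compounds at the limit, no step size has been observed for any change, and nothing shown indicates that this change moves a compound into the measurable range. The step is expected to be a step that the limit leaves unreadable from compound 1 to compound 3, none beyond the scatter. Compound 3 is therefore expected to give about 8000 nM, within 2000 nM to 40000 nM, and most probably again only a limit.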

Compound 3, half-maximal inhibitory concentration: > 4000 nM
Compound 3 was reported as a limit (the forecaster's own chance of this, stated with the estimate: 80%); the middle value lies beyond the limit too.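

In this assay compound 3 gives > 4000 nM and this is a limit, not a number. Within the data shown here, compound 1 also stops at a limit, so no step from compound 1 to compound 3 can be read: the limit of > 4000 nM in this assay, at which 3 of the 3 values shown sit. The compounds shown leave open how far apart they truly stand and what change to the shared core would give a measurable value in this assay at all.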